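The source may report more compounds than this note shows. Statements on the series, on what has been measured and on what is new or still open speak of the compounds shown alone.

Working notes on the series. In a functional assay on K562 cells (Homo sapiens) for cytotoxicity, read by MTT assay, with a stated time of 24 h (a higher number here means a weaker inhibitor, a lower number a stronger inhibitor), compound 1 `COc1ccc(/C=C2\CN(C)C/C(=C\c3ccccc3F)C2=O)cc1OC` gives 18000 nM and compound 2 `COc1cc(/C=C2\CN(C)C/C(=C\c3ccccc3F)C2=O)cc(OC)c1OC` gives 4340 nM, so compound 2 holds the lower of the two numbers. Next in line is compound 3 `COc1cc(/C=C2\CN(C)C/C(=C\c3cc(OC)c(OC)c(OC)c3)C2=O)cc(OC)c1`, and the change is 3,5-dimethoxyphenyl in place of 2-fluorophenyl on a double-bonded chain carbon bound to a double-bonded ring carbon. Within the data shown here, only one measured step bears on this: a 4.1-fold lower number from compound 1 to compound 2 (0.62 log units; beyond the scatter), a modest move for methoxy in place of hydrogen on an aromatic carbon. That step lies at a different place in the molecule, and it also adds methoxy, so it offers only indirect guidance. Among the measured compounds shown here, no measured step covers the loss of 2-fluorophenyl. In this assay, a shift no larger than that modest one is therefore expected, leaning towards a lower number. The expected step is a 1.4-fold lower number from compound 2 to compound 3 (0.16 log units; within the scatter). The estimate for compound 3 is 3000 nM, with an expected range of 900 nM to 10000 nM.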

Compound 3, half-maximal inhibitory concentration: 3470 nM
Compound 3: middle estimate off by 1.2-fold (0.06 log units), on the low side; the measured number falls inside the stated range.
By their numbers in this assay, from the lowest: compounds 3 and 2 (each within the scatter of the next); then compound 1.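

In this assay, 3,5-dimethoxyphenyl in place of 2-fluorophenyl on a double-bonded chain carbon bound to a double-bonded ring carbon gives a 1.3-fold lower number from compound 2 to compound 3 (0.10 log units; within the scatter) and so yields no shift that can be told from the scatter. Among these compounds, this is the first reading at this position, and it shows that the fluorine-bearing ring can be exchanged for a group of 10 heavy atoms against 7, with 2 hydrogen-bond acceptors added, and the number stays within the scatter. Nothing available accounts for this flat step.

On these data alone, whether the same holds for a non-aromatic group here, such as a carboxylic acid or an amine on a longer chain, remains open. Also open, as far as these compounds go, is whether a nitrile on this aromatic ring would leave the number equally unmoved.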